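The source may report more compounds than this note shows. Statements on the series, on what has been measured and on what is new or still open speak of the compounds shown alone.

Compound 1, `CCc1ccc(N2C(=O)C=CC2OCC(F)(F)F)cc1`: 4470 nM
Compound 2, `O=C1C=CC(OCC(F)(F)F)N1c1ccc(Cl)cc1F`: 6210 nM
Compound 3, `O=C1C=CC(OCC(F)(F)F)N1c1ccc(F)c(Cl)c1`: 6320 nM

In a functional assay on K562 cells (Homo sapiens) for inhibition (a higher number here means a weaker inhibitor, a lower number a stronger inhibitor), compound 1 gives 4470 nM. Compound 2 gives 6210 nM and compound 3 gives 6320 nM; the gaps from compound 1 to each of these lie within the scatter, so the three numbers cannot be told apart, and all three sit in the weak range.

Compound 4, `COC(=O)c1ccc(N2C(=O)C=CC2OCC(F)(F)F)cc1`, has not yet been measured. It differs from compound 1 in one place: methoxycarbonyl in place of ethyl on an aromatic carbon. Among the measured compounds shown here, no measured pair of the three shows the effect of this kind of exchange, so nothing in the data points to a direction. The step from compound 1 to compound 4 is expected to be a 1.1-fold higher number from compound 1 to compound 4 (0.05 log units; within the scatter), not beyond the scatter. For compound 4 the estimate in this assay is 5000 nM, in the range 1500 nM to 16000 nM.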

Compound 4, half-maximal inhibitory concentration: 14700 nM
For compound 4 the middle estimate is 2.9-fold (0.47 log units) below the measured one; the range from low to high includes it.
By their numbers in this assay, from the lowest: compounds 1, 2 and 3 (each within the scatter of the next); then compound 4.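

In this assay, methoxycarbonyl in place of ethyl on an aromatic carbon, para to a large group, gives a 3.3-fold higher number from compound 1 to compound 4 (0.52 log units; beyond the scatter), a modest step beyond the scatter. Among the compounds shown here, this is the first readable step, and it shows that inhibition at this position does depend on the group placed there. No measurement at hand speaks to the reason for this step.

On these data alone, whether an amine, a carboxylic acid or a longer chain here would match ethyl or fall further stays open. So does whether the exchange would act alike on compound 2 or compound 3.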